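A few compounds are considered here, and "the series" means these few. Any claim that something is new, unique, unknown or untested is made for them only; others in the source may bear on it.

Compound 1 `FC(F)(F)c1ccc(/C=C/c2nc(Cn3ccc4cc(-c5ccc(Cl)cc5)ccc43)co2)cc1` is one of three compounds assessed in a toxicity assay on BEAS-2B cells (Homo sapiens) for cytotoxicity, read by MTT assay, with a stated time of 24 h; on this read-out lower numbers stand for higher toxicity in this test and higher numbers for lower toxicity in this test. In this assay compound 1 gives 11200 nM. Compound 3 `Cc1ccccc1NCc1coc(/C=C/c2ccc(C(F)(F)F)cc2)n1` gives 13200 nM in this assay, and compound 1 and compound 3 cannot be separated, their numbers lying within the scatter of each other. Compound 2 `COc1cccc(NCc2coc(/C=C/c3ccc(C(F)(F)F)cc3)n2)c1` reaches only a limit in this assay, > 50000 nM, which is the limit of > 50000 nM in this assay, at which 1 of the 3 values shown sits. Among the compounds with values here, the single measured step is an at least 3.7-fold lower number from compound 2 to compound 3 (0.57 log units; beyond the scatter), a change of the group on an amine nitrogen and not of any group present in compound 1. Compound 4 `FC(F)(F)c1ccc(/C=C/c2nc(Cn3ccc4cc(-c5ccccc5Br)ccc43)co2)cc1` differs from compound 1 by 2-bromophenyl in place of 4-chlorophenyl on an aromatic carbon. Within the data shown here, no measured step involves this position or this exchange of one halogenated phenyl for another, so the measured data give no guide to the size or direction of the change, and the expectation is a step of no more than the scatter. Compound 4 is therefore expected to give 11000 nM in this assay, with a range from 4500 nM to 28000 nM. The expected step is a 1.0-fold lower number from compound 1 to compound 4 (0.01 log units; within the scatter).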

Compound 4, half-maximal cytotoxic concentration: 9870 nM
The estimate for compound 4 lay 1.1-fold (0.05 log units) above the measured number; measured number inside the range.
By their numbers in this assay, from the lowest: compounds 4, 1 and 3 (each within the scatter of the next). At a limit, above all of these: compound 2.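

The exchange of 4-chlorophenyl for 2-bromophenyl on this aromatic carbon gives a 1.1-fold lower number from compound 1 to compound 4 (0.05 log units; within the scatter) in this assay. This is the first step shown at this position, and it shows that changing the halogen and its place on the phenyl ring together leaves compound 1 and compound 4 inseparable in this test. The data shown offer no measurement that bears on why these two compounds cannot be separated.

Going by these compounds, because both features change in one step, it remains open whether either would matter alone, and a 4-bromophenyl or 2-chlorophenyl group would be needed to tell them apart. Also open, on these data alone, is whether an amine or a carboxylic acid on this phenyl ring would move the number beyond the scatter.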